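This account rests on a few compounds, and the source may have more. Where it says the series, first, only, none or still open, it means among the compounds named here.

Measured compounds in a functional assay on NIH3T3 cells (Mus musculus); on this read-out higher numbers stand for an effect only at larger amounts of compound and lower numbers for an effect already at smaller amounts:
Compound 1 `COC(=O)[C@H](CCSC)NC(=O)c1ccc(CNCc2c[nH]cn2)cc1-c1ccccc1C` gives 25 uM.
Compound 2 `CSCC[C@H](NC(=O)c1ccc(CNCc2c[nH]cn2)cc1-c1ccccc1C)C(=O)OC(C)C` gives 10 uM.

Among the compounds with values here, on these two numbers compound 2 stands lowest; compound 1 is its only neighbour, separated by the step of a 2.5-fold lower number from compound 1 to compound 2 (0.40 log units; beyond the scatter), which lies beyond the scatter. Compound 3 `CCOC(=O)[C@H](CCSC)NC(=O)c1ccc(CNCc2c[nH]cn2)cc1-c1ccccc1C` is not yet measured in this assay. It differs from compound 2 by hydrogen in place of methyl on a saturated chain carbon bound to an oxygen next to a carbonyl group and a saturated chain carbon, read one bond further out as isopropyl to ethyl on the ester of the shared core. Within the data shown here, the only measured step that bears on this change is a 2.5-fold lower number from compound 1 to compound 2 (0.40 log units; beyond the scatter): going from methyl to isopropyl at the same position lowered the number. Ethyl lies between methyl and isopropyl in that short series, so a number between those of compound 1 and compound 2 is expected, with the step of a 1.5-fold higher number from compound 2 to compound 3 (0.18 log units; within the scatter) most likely staying within the scatter. For compound 3 the estimate in this assay is 15 uM, expected to fall between 7 uM and 32 uM.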

Compound 3, concentration for half-maximal effect: 10 uM
The estimate for compound 3 lay 1.5-fold (0.18 log units) above the measured number; low and high end bracket the measured number.
By their numbers in this assay, from the lowest: compounds 2 and 3 (each within the scatter of the next); then compound 1.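

In this assay, the lower number seen at the ester does not require the isopropyl group: with the ethyl ester the change is already a 2.5-fold lower number from compound 1 to compound 3 (0.40 log units; beyond the scatter). Going from isopropyl to ethyl gives no change at the digits printed from compound 2 to compound 3 (within the scatter), so the extra methyl on the saturated chain carbon of compound 2 adds nothing that can be read here, and the two esters cannot be ranked. Nothing at hand explains why the number shifts between methyl and ethyl but not between ethyl and isopropyl.

As far as these compounds go, whether a longer chain such as n-butyl, a tert-butyl ester or a free carboxylic acid would keep this level remains open. All three compounds share one core, so how a change outside the ester would read in this assay is open too.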